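Acetyl to dimethylamino on the phenyl of compound 1

The source may report more compounds than this note shows. Statements on the series, on what has been measured and on what is new or still open speak of the compounds shown alone.

Among the measured compounds shown here, compound 1 `COc1cc(C)cc(-c2c(-c3ccnc(-c4ccc(C(C)=O)cc4)c3)cnn2CC#N)c1` gives -10% in a functional assay on OVCAR-3 cells (Homo sapiens) for cytotoxicity, read by sulforhodamine B assay, with a stated time of 48 h, tested at 1 uM (a lower number here means a stronger effect, a higher number a weaker effect of the compound at the concentration tested), and holds the highest of the two numbers measured so far; compound 2 `COc1cc(C)cc(-c2nn(CC#N)cc2-c2ccnc(-c3ccc(N(C)C)cc3)c2)c1` gives -41% in this assay, a number lower than compound 1 by more than the usual scatter. Compound 3 `COc1cc(C)cc(-c2c(-c3ccnc(-c4ccc(N(C)C)cc4)c3)cnn2CC#N)c1` is not yet measured in this assay. It differs from compound 1 in one place: dimethylamino in place of acetyl on an aromatic carbon. For the measured compounds named here, no measured pair shows this exact step, so its size is not known from data. Compound 2 also carries a 4-(dimethylamino)phenyl and gives -41%, which points to a lower number for compound 3 than for compound 1. Compound 3 is therefore expected to come out at -30%, with a plausible range from -55% to -5%, a step of a number 20 percentage points lower from compound 1 to compound 3 (beyond the scatter) toward a stronger effect that is expected to exceed the scatter, though with wide uncertainty.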

Compound 3, a percentage reported as activity, at one concentration (the size of the read-out at that concentration, not a potency): 3%
Compound 3: the middle estimate sits 33 percentage points below what was measured; the whole stated range lies below it.
By their numbers in this assay, from the lowest: compound 2; then compound 1; then compound 3.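

In this assay, among the compounds shown here, the exchange of 4-acetylphenyl for 4-(dimethylamino)phenyl gives the first directly readable step at this position, a number 13 percentage points higher from compound 1 to compound 3 (beyond the scatter), toward a weaker effect. Compound 2 also carries 4-(dimethylamino)phenyl and gives -41%, while compound 3 gives 3%, so in these compounds that group alone does not fix the read-out, and the arrangement of the shared core remains a variable to consider. No available measurement accounts for the direction or size of this step.

From the compounds shown here alone, the read-outs for a primary amine, a carboxylic acid or a longer chain at this position remain open. Also open, going by these compounds, is whether the exchange of acetyl for dimethylamino would run the same way on the core of compound 2.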